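The compounds below may be only part of what the source reports. "The series", "measured", "known", "first", "only" and "open" are said of these compounds alone.

Working notes on the series, measured in an assay on CV-1 cells for activation of retinoic acid receptor beta (Homo sapiens); a higher number here means that more compound is needed for the effect, a lower number that less compound is needed.

Going by the values given here, compound 3 `C/C(=C\c1ccc(C(=O)O)cc1)c1ccc2c(c1)C(C)(C)CO2` stands at the top of the three numbers so far: in this assay compound 3 gives 320 nM. The nearest of the others is compound 1 `COC(=O)c1ccc(/C=C(\C)c2ccc3c(c2)C(C)(C)CCS3)cc1`, which in this assay gives 110 nM, a gap beyond the scatter. Furthest away is compound 2 `CC(/C=C/C=C(\C)c1ccc2c(c1)C(C)(C)CCO2)=C\C(=O)O`, which in this assay gives 72 nM, again beyond the scatter. Compound 3 thus needs more compound than either of the other two, while the numbers for compound 1 and compound 2 lie within the scatter of each other and carry no order between them.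

The next compound, compound 4 `COC(=O)c1ccc(/C=C(\C)c2ccc3c(c2)C(C)(C)CO3)cc1`, differs from compound 3 in one place: methyl in place of hydrogen on an oxygen next to a carbonyl group. Among the compounds with values here, no pair of measured compounds shows this change by itself; compound 1 carries the methoxycarbonyl group and compound 3 the carboxy group, but the two differ at the same time in their cores, so their values show nothing clean about this one change.

The expectation for compound 4 is therefore a modest step downward, a 1.6-fold lower number from compound 3 to compound 4 (0.20 log units; within the scatter), with the values of compound 1 and compound 3 as loose guides, and the estimate for compound 4 in this assay is 200 nM, within the range 70 nM to 600 nM.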

Compound 4, half-maximal effective concentration: 430 nM
Estimate against measurement, compound 4: 2.2-fold (0.33 log units) below, and the stated range covers the measured number.
By their numbers in this assay, from the lowest: compounds 2 and 1 (each within the scatter of the next); then compounds 3 and 4 (each within the scatter of the next).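

With the step of a 1.3-fold higher number from compound 3 to compound 4 (0.13 log units; within the scatter) in this assay, the series now has a clean reading of methyl in place of hydrogen on an oxygen next to a carbonyl group. Going from carboxy to methoxycarbonyl on this shared core leaves the number within the scatter, which compound 1 and compound 3 could not show, as those two also differ in their cores. At this position, therefore, compound 3 and compound 4 carry no order between them, and nothing on hand gives a reason for this result.

Still open, on these data alone, is whether the same change reads alike on the core of compound 1 or on the core and chain of compound 2, as this single pair says nothing about either. Also open, as far as these compounds go, is how an ethyl ester, a primary amide or a hydroxamic acid would read in place of the carboxy group on the core shared by compound 3 and compound 4 in this assay.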